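A few compounds are considered here, and "the series" means these few. Any claim that something is new, unique, unknown or untested is made for them only; others in the source may bear on it.

Working notes on the series, read in a functional assay on HepG2 cells (Homo sapiens) for antiproliferative activity, read by CCK-8 assay, with a stated time of 72 h; a higher number here means a weaker inhibitor, a lower number a stronger inhibitor. Compound 1 (`Cc1ccc(Nc2nc(Cl)nc3c2ncn3Cc2ccc(C(=O)Nc3ccccc3N)cc2)cc1`) gives 860 nM, compound 2 (`Nc1ccccc1NC(=O)c1ccc(Cn2cnc3c(Nc4ccc(-c5ccccn5)cc4)nc(Cl)nc32)cc1`) gives 30100 nM and compound 3 (`Nc1ccccc1NC(=O)c1ccc(CNc2nc(Cl)nc3c2ncn3C2CCCC2)cc1`) gives 3430 nM. Compound 2 has the highest number of the three and is the weakest inhibitor here, with its gaps to both others beyond the scatter.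

The next comparison runs to compound 4 (`Nc1ccccc1NC(=O)c1ccc(Cn2cnc3c(Nc4cccc(Cl)c4)nc(Cl)nc32)cc1`), not yet measured. Here 3-chlorophenyl stands in place of 4-(pyridin-2-yl)phenyl on a nitrogen on an aromatic ring: 3-chlorophenyl in place of 4-(pyridin-2-yl)phenyl on a nitrogen on an aromatic ring.

Going by the values given here, one measured step bears on this change: a 35-fold higher number from compound 1 to compound 2 (1.54 log units; beyond the scatter). That large step came with pyridin-2-yl in place of methyl on an aromatic carbon. Among the compounds with values here, no single-place step links compound 3 to the others, so it gives no direct guide. Compound 4 lacks the pyridin-2-yl group, as does compound 1 at 860 nM, so a large step to a lower number is expected in this assay. Within the data shown here, no measured compound carries 3-chlorophenyl, so the range stays wide.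

The estimated change is a 17-fold lower number from compound 2 to compound 4 (1.22 log units; beyond the scatter). For compound 4 the estimated value is 1800 nM, with an expected range of 500 nM to 7000 nM.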

Compound 4, half-maximal inhibitory concentration: 9800 nM
Compound 4: the middle estimate sits 5.4-fold (0.74 log units) below what was measured; measured number outside the range, above it.
By their numbers in this assay, from the lowest: compound 1; then compound 3; then compound 4; then compound 2.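

In this assay, 3-chlorophenyl in place of 4-(pyridin-2-yl)phenyl on a nitrogen on an aromatic ring gives a 3.1-fold lower number from compound 2 to compound 4 (0.49 log units; beyond the scatter), a modest step that closes only part of the distance to compound 1. Set against 4-methylphenyl at the same place, 3-chlorophenyl gives an 11-fold higher number from compound 1 to compound 4 (1.06 log units; beyond the scatter), a large step, so removing the pyridin-2-yl group is not enough on its own to restore the number of compound 1, and this place responds strongly to a change between two singly substituted phenyl groups. No measurement here accounts for either step.

Compound 1 and compound 4 differ in both the substituent and its place on the phenyl ring, so the shown compounds cannot say whether chlorine in place of methyl or the shift of the substituent carries the large step. An unsubstituted phenyl, a 4-chlorophenyl and a 3-methylphenyl on this nitrogen would separate those two readings, while a methoxy or an amine on the ring would show how far the response extends beyond these groups.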